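Swapping One Ring Group on a Shared Core

The source may hold more compounds than are shown below. What is called first, only, known or untested is meant among the compounds shown, and "the series" means these compounds.

The three measured compounds, with their values in an in vitro functional assay on HEK285-7 cells for antagonist activity at prostaglandin D2 receptor 2 (Homo sapiens), read by BRET and beta-arrestin recruitment; a higher number here means a larger maximal response, a lower number a smaller maximal response:
compound 1 `Cc1nc(-c2ccc(Cl)cc2)c(CC(=O)O)s1` gives 50%;
compound 2 `NS(=O)(=O)c1cccc(-c2nc(C(c3ccc(F)cc3)c3ccc(F)cc3)sc2CC(=O)O)c1` gives 55%;
compound 3 `O=C(O)Cc1sc(C(c2ccccc2)c2ccc(Cl)cc2)nc1-c1ccc(F)cc1` gives 80%.

Among these three numbers, compound 2 stands second highest. Compound 1 is its nearest neighbour, and the two lie within the usual scatter of each other, so nothing separates them with confidence. Compound 3 is the furthest away, with a maximal response that lies beyond the scatter above compound 2.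

Compound 4 `O=C(O)Cc1sc(C(c2ccc(F)cc2)c2ccc(F)cc2)nc1-c1ccnc(O)c1` has not been measured yet. It differs from compound 2 in one place: 2-hydroxypyridin-4-yl in place of 3-sulfamoylphenyl on an aromatic carbon. Among the compounds with values here, no two measured compounds differ in only one place, so no measured step shows what such a swap does here. The change from compound 2 to compound 4 is therefore expected to shift the maximal response by at most the size of the scatter, in either direction, and the step of no change at the digits printed from compound 2 to compound 4 (within the scatter) is expected to be small. Compound 4 is estimated to give 55% in this assay, within a range from 35% to 78%.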

Compound 4, largest response reached (reported as efficacy), in percent of the reference or control that the assay uses: 60%
Estimate against measurement, compound 4: 5 percentage points below; low and high end bracket the measured number.
By their numbers in this assay, from the lowest: compounds 1, 2 and 4 (each within the scatter of the next); then compound 3.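

The swap at this position, on the aromatic carbon next to the ring nitrogen, now has a measured step in this assay: a number 5 percentage points higher from compound 2 to compound 4 (within the scatter), so the two compounds cannot be told apart. The 3-sulfamoylphenyl group, with its ring of carbon only, can thus be exchanged for 2-hydroxypyridin-4-yl, with a hetero atom in its ring, without a maximal response that can be distinguished from the first. No data shown here point to why the response holds across this swap.

Compound 3 gives 80% but differs from compound 4 in more than one place, so that number says nothing about this position. Going by these compounds, whether a simple amine or a methoxy group on this aromatic carbon would also leave the response in the same range stays open.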